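The source may hold more compounds than are shown below. What is called first, only, known or untested is meant among the compounds shown, and "the series" means these compounds.

In an assay on HEK293 cells for positive allosteric modulation of metabotropic glutamate receptor 3 (Rattus norvegicus), read by thallium flux, with a stated time of 2.5 min (on this read-out lower numbers stand for smaller maximal responses and higher numbers for larger maximal responses), compound 1 `Cc1c(OCCCCOc2ccccc2C(=O)O)ccc(C(=O)CC(C)C)c1O` gives 28.1%, and compound 2 `Cc1cc(OCCCCOc2ccc(C(=O)CC(C)C)c(O)c2C)ccc1C(=O)O` gives 41.9%. Going by the values given here, the one recorded step, a number 13.8 percentage points higher from compound 1 to compound 2 (beyond the scatter), moved the carboxylic acid and the methyl group on the aryl ether ring and raised the maximal response. On these two numbers compound 2 stands highest. Compound 3 `Cc1ccc(C(=O)O)cc1OCCCCOc1ccc(C(=O)CC(C)C)c(O)c1C` again rearranges that same ring: 5-carboxy-2-methylphenyl in place of 4-carboxy-3-methylphenyl on an oxygen on a saturated carbon. Only the earlier step bears on this change, and it was modest, so a shift of similar size or none beyond the scatter is expected: compound 3 is estimated at 36%, ranging from 22% to 52%, a step of a number 5.9 percentage points lower from compound 2 to compound 3 (within the scatter) expected.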

Compound 3, largest response reached (reported as percent of maximum), in percent of the reference or control that the assay uses: 29.4%
The estimate for compound 3 lay 6.6 percentage points above the measured number; low and high end bracket the measured number.
By their numbers in this assay, from the lowest: compounds 1 and 3 (each within the scatter of the next); then compound 2.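

Rearranging the same groups on this ring does not preserve the higher response: 5-carboxy-2-methylphenyl on the oxygen gives a number 12.5 percentage points lower from compound 2 to compound 3 (beyond the scatter) and so loses the gain seen with 4-carboxy-3-methylphenyl. Set against 2-carboxyphenyl, it gives a number 1.3 percentage points higher from compound 1 to compound 3 (within the scatter) and the two cannot be told apart, even though only 5-carboxy-2-methylphenyl carries a methyl. Nothing available explains why these arrangements differ. Open, on these data alone, is whether 4-carboxy-3-methylphenyl keeps its advantage with a tetrazole in place of the carboxylic acid, or with a chlorine in place of the methyl.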